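The source may hold more compounds than are shown below. What is called first, only, known or untested is meant among the compounds shown, and "the series" means these compounds.

Compound 1 `CCNC(=O)c1noc(-c2cc(C(C)C)c(O)cc2O)c1-c1cc(COCC(=O)OC)no1` gives "not determined" (no result reported) in the assay below
Compound 2 `CCNC(=O)c1noc(-c2cc(C(C)C)c(O)cc2O)c1-c1cc(CN(C)C)no1` gives 31 nM in the assay below

Going by the values given here, in a functional assay on A2780 cells (Homo sapiens) for inhibition (on this read-out higher numbers stand for weaker inhibition and lower numbers for stronger inhibition), compound 2 gives 31 nM as the only actual number so far, so it cannot yet be ranked against another compound. Compound 3 `CCNC(=O)c1noc(-c2cc(C(C)C)c(O)cc2O)c1-c1cc(CN2CCCCC2)no1` keeps the shared core. The change piperidin-1-yl in place of dimethylamino on a saturated chain carbon bound to an aromatic carbon puts piperidin-1-yl in place of dimethylamino on a saturated chain carbon bound to an aromatic carbon. Among the compounds with values here, no measured step guides this change. The estimated 1.0-fold lower number from compound 2 to compound 3 (0.01 log units; within the scatter) is therefore small, with no shift expected beyond the usual scatter in either direction. For compound 3 the expected value is 30 nM with an estimated range from 12 nM to 80 nM in this read-out.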

Compound 3, half-maximal inhibitory concentration: 62 nM
For compound 3 the middle estimate is 2.1-fold (0.32 log units) below the measured one; the measured number falls inside the stated range.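

Going by these compounds alone, on a saturated chain carbon bound to an aromatic carbon, putting piperidin-1-yl in place of dimethylamino gives a 2.0-fold higher number from compound 2 to compound 3 (0.30 log units; within the scatter) in this assay as the first readable step at this position. The larger amine, with 6 heavy atoms instead of 3 and a six-membered ring, therefore leaves the read-out within the usual scatter. Nothing measured here offers an explanation for this result. The step involving compound 1 cannot be read, as it has no reported number. Going by these compounds, whether a morpholine ring, a primary amine or a carboxylic acid at this position would behave similarly remains open.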